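The source may hold more compounds than are shown below. What is called first, only, known or untested is meant among the compounds shown, and "the series" means these compounds.

Measured in a functional assay on MCF7 cells (Homo sapiens) for antiproliferative activity, read by MTT assay, with stated times of 24 h and 72 h; a lower number here means a stronger inhibitor, a higher number a weaker inhibitor:
- compound 1 `COc1ccc([C@@H]2[C@H](Oc3ccccc3)C(=O)N2c2cc(OC)c(OC)c(OC)c2)cc1[N+](=O)[O-]`: 69000 nM
- compound 2 `COc1cc(N2C(=O)[C@@H](Oc3ccccc3)[C@H]2c2cccc([N+](=O)[O-])c2)cc(OC)c1OC`: 30000 nM

Compound 2 has the lower of the two numbers. Going by the values given here, the one measured step, a 2.3-fold lower number from compound 1 to compound 2 (0.36 log units; beyond the scatter), puts hydrogen in place of methoxy on an aromatic carbon, and it is modest. Compound 3 `COc1cc(N2C(=O)[C@@H](Oc3ccccc3)[C@H]2c2ccc(O)cc2)cc(OC)c1OC` differs from compound 2 elsewhere: 4-hydroxyphenyl in place of 3-nitrophenyl on a saturated ring carbon. In words, this is 4-hydroxyphenyl in place of 3-nitrophenyl on a saturated ring carbon. Among the compounds with values here, no measured step covers this swap, so the direction is uncertain, and only a loose expectation of a modest to moderate drop is possible. The expected change in this assay is a 3.3-fold lower number from compound 2 to compound 3 (0.52 log units; beyond the scatter). For compound 3 the estimated value is 9000 nM, with an expected range of 1000 nM to 45000 nM.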

Compound 3, half-maximal inhibitory concentration: 48000 nM
The estimate for compound 3 lay 5.3-fold (0.73 log units) below the measured number, outside the stated range (above it).
By their numbers in this assay, from the lowest: compounds 2, 3 and 1 (each within the scatter of the next, the first and the last beyond it).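

In this assay, 4-hydroxyphenyl in place of 3-nitrophenyl on this saturated ring carbon gives a 1.6-fold higher number from compound 2 to compound 3 (0.20 log units; within the scatter), and 4-hydroxyphenyl in place of 4-methoxy-3-nitrophenyl gives a 1.4-fold lower number from compound 1 to compound 3 (0.16 log units; within the scatter). So the aromatic ring at this position can lose its nitro group and carry a hydroxyl instead without a change that stands out from the scatter. Nothing available explains this result. Still open, from the compounds shown here alone, is whether an amine or a carboxylic acid on this ring would move the number beyond the scatter. The same question holds for a plain phenyl ring.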